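Acylating the Amine Nitrogen of Compound 2

A few compounds are considered here, and "the series" means these few. Any claim that something is new, unique, unknown or untested is made for them only; others in the source may bear on it.

Compound 2 `COc1ccc(CNc2cc(OC)c(OC)c(OC)c2)cc1C` and compound 1 `C/C=C/C(=O)N(Cc1cccc(O)c1)c1cc(OC)c(OC)c(OC)c1` have both been tested in a functional assay on KYSE-450 cells (Homo sapiens) for inhibition, read by MTT assay, with a stated time of 48 h; on this read-out higher numbers stand for weaker inhibition and lower numbers for stronger inhibition. Compound 2 gives 73800 nM, the higher of the two numbers, whereas compound 1 gives 14700 nM. Compound 3 `C/C=C/C(=O)N(Cc1ccc(OC)c(C)c1)c1cc(OC)c(OC)c(OC)c1` differs from compound 2 by (prop-1-en-1-yl)carbonyl in place of hydrogen on a nitrogen on an aromatic ring. Because compound 1 carries the same (prop-1-en-1-yl)carbonyl on its nitrogen and gives 14700 nM, a step toward stronger inhibition, beyond the scatter, is expected, a 4.1-fold lower number from compound 2 to compound 3 (0.61 log units; beyond the scatter). Compound 3 is therefore estimated at 18000 nM in this assay, with a range from 6000 nM to 50000 nM.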

Compound 3, half-maximal inhibitory concentration: 32900 nM
Compound 3: middle estimate off by 1.8-fold (0.26 log units), on the low side; the range from low to high includes it.
By their numbers in this assay, from the lowest: compound 1; then compound 3; then compound 2.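

In this assay, (prop-1-en-1-yl)carbonyl in place of hydrogen on the nitrogen gives a modest gain with the 4-methoxy-3-methylphenyl group held constant (a 2.2-fold lower number from compound 2 to compound 3 (0.35 log units; beyond the scatter)). With that carbonyl group held constant, 4-methoxy-3-methylphenyl in place of 3-hydroxyphenyl costs a step of the same printed size (a 2.2-fold higher number from compound 1 to compound 3 (0.35 log units; beyond the scatter)), so the aromatic group on the saturated chain carbon also matters for the amide. Nothing available here explains either step.

The compounds shown leave open whether a saturated propanoyl group or a sulfonyl group on the nitrogen would give the same gain. They also leave open whether the methoxy or the methyl group accounts for the step from the 3-hydroxyphenyl group.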